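The compounds below may be only part of what the source reports. "The series", "measured", "known", "first", "only" and "open" are said of these compounds alone.

Measured compounds:
compound 1, `CCOc1ccc2c(C)cc(=O)oc2c1COC(=O)/C=C/c1ccccc1` — 40.8 nM
compound 2, `CCOc1ccc2c(C)cc(=O)oc2c1COC(=O)/C=C/c1ccc(OC)cc1` — 5.4 nM
compound 3, `COc1ccc(C(=O)OCc2c(OC(C)C)ccc3c(C)cc(=O)oc23)cc1OC` — 20.2 nM

All three were run in a functional assay on cells for positive allosteric modulation, with A2780/Taxol (Homo sapiens) as the target, read by MTT assay, with a stated time of 48 h, tested at 10 uM; on this read-out higher numbers stand for weaker inhibition and lower numbers for stronger inhibition. Among the compounds with values here, the one counted step among them is a 7.6-fold lower number from compound 1 to compound 2 (0.88 log units; beyond the scatter), the change being (methoxy in place of hydrogen on an aromatic carbon). Compound 3 and compound 1 share no single-point relation; the difference between the two cores is not broken down here, and their values simply sit as given above.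

Compound 4, `COc1cc(C(=O)OCc2c(OC(C)C)ccc3c(C)cc(=O)oc23)cc(OC)c1OC`, is still unmeasured. It differs from compound 3 by methoxy in place of hydrogen on an aromatic carbon. This is the same kind of change as that from compound 1 to compound 2, but not the same: in the earlier case the entering methoxy sits para to a large group, whereas here it sits ortho to a methoxy group, meta to a large group and meta to a methoxy group. The earlier step rests on one pair only, and the surroundings of the place differ, so a smaller step is expected for compound 4 in this assay, namely a 2.0-fold lower number from compound 3 to compound 4 (0.31 log units; beyond the scatter). For compound 4 the estimate in this assay is 10 nM, within 4 nM to 30 nM.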

Compound 4, half-maximal inhibitory concentration: 11.2 nM
The estimate for compound 4 lay 1.1-fold (0.05 log units) below the measured number; the range from low to high includes it.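

In this assay, methoxy in place of hydrogen on an aromatic carbon does not carry over at one size from one core to the other: the same change on two cores in this assay, a 7.6-fold lower number (0.88 log units; beyond the scatter) from compound 1 to compound 2 and a 1.8-fold lower number (0.26 log units; within the scatter) from compound 3 to compound 4, 4.2-fold (0.62 log units) apart, beyond the scatter of two such steps On the core of compound 3 the change gives a 1.8-fold lower number from compound 3 to compound 4 (0.26 log units; within the scatter), so on this core alone the step cannot be told apart from repeat-to-repeat variation. This does not show what separates the two steps: the pairs differ both in their cores and in the surroundings of the entering methoxy, and with one pair on each core these differences cannot be pulled apart.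

The compounds shown leave open whether the step would stay the same if methoxy entered the core of compound 1 at the place it takes in compound 4, or the core of compound 3 at the place it takes in compound 2. Also open, on these data alone, is how a hydroxy group, an amine or a fluorine atom would behave at these places in place of methoxy.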